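Extending the Hydroxymethyl Side Chain on a Shared Uracil Core

The source may hold more compounds than are shown below. What is called first, only, known or untested is meant among the compounds shown, and "the series" means these compounds.

Compound 1, `O=c1ccn(COC(CO)CO)c(=O)[nH]1`: in a functional assay on HepG2 cells (Homo sapiens) for cytotoxicity (on this read-out lower numbers stand for higher toxicity in this test and higher numbers for lower toxicity in this test), compound 1 gives > 462000 nM, which is a limit of the test rather than a number.
Compound 2, `CCc1cn(COC(CO)CO)c(=O)[nH]c1=O`: in this assay compound 2 gives > 410000 nM, again a limit.
Compound 3, `O=c1[nH]c(=O)n(COC(CO)CO)cc1CO`: in this assay compound 3 gives > 406000 nM, also a limit.

Every value here is a limit, so none of the three compounds shows measurable toxicity in this assay, and no order among them can be read. Compound 3 therefore stands at a limit, as do the two further values (the limit of > 406000 nM in this assay, at which 1 of the 3 values shown sits, (the limit of > 410000 nM in this assay, at which 1 of the 3 values shown sits), (the limit of > 462000 nM in this assay, at which 1 of the 3 values shown sits)).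

Compound 4, `O=c1[nH]c(=O)n(COC(CO)CO)cc1CCO`, differs from compound 3 by hydroxymethyl in place of hydroxy on a saturated chain carbon bound to an aromatic carbon. Going by these compounds, the measured steps that touch the same position are a step that the two limits leave unreadable from compound 1 to compound 3 and a step that the two limits leave unreadable from compound 2 to compound 3; both lie between limits, so their size is unknown, and a step that the two limits leave unreadable from compound 1 to compound 2 gives no more. Among the measured compounds shown here, nothing among the measured compounds suggests a step beyond the scatter in this assay, and the most likely outcome for compound 4 is another limit.

Compound 4 is therefore expected to give about 450000 nM in this assay, with a range from 200000 nM to 2000000 nM. That estimate means an expected step that the limit leaves unreadable from compound 3 to compound 4.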

Compound 4, half-maximal cytotoxic concentration: > 384000 nM
Compound 4: no number, only a limit; the forecaster's own chance of this, stated with the estimate: 90%; the middle value lies beyond the limit too.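

In this assay compound 4 gives > 384000 nM, again a limit, so its steps to compound 1, compound 2 and compound 3 cannot be read. The four compounds leave open whether any side chain on the shared core would give a measurable value in this assay.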